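Sulfonamide piperidine amides: replacing the amide ring

The compounds below may be only part of what the source reports. "The series", "measured", "known", "first", "only" and "open" are said of these compounds alone.

Measured compounds:
compound 1, `CCN(CC)S(=O)(=O)c1ccc(S(=O)(=O)N2CCC[C@@H](C(=O)N3CCC(O)CC3)C2)cc1`, in a functional assay on BXPC-3 cells (Homo sapiens) for inhibition, read by MTT assay, with a stated time of 7 days (a higher number here means a weaker inhibitor, a lower number a stronger inhibitor), gives 4710 nM.
compound 2, `O=C([C@@H]1CCCN(S(=O)(=O)c2ccc(S(=O)(=O)N3CC[C@H](O)C3)cc2)C1)N1CCC(F)(F)CC1`, in this assay gives 580 nM.

Of the two measured compounds, compound 1 stands with the highest number. Compound 2 gives a lower number, and the gap between them lies beyond the scatter of repeated measurements, so compound 2 is the stronger inhibitor of the pair. Among the compounds with values here, compound 2 also differs from compound 1 in more than one place, so no single step between them can be read.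

Compound 3, `CCN(CC)S(=O)(=O)c1ccc(S(=O)(=O)N2CCC[C@@H](C(=O)N3CC[C@@H](OC)C3)C2)cc1`, has not yet been measured. It differs from compound 1 in one place: 3-methoxypyrrolidin-1-yl in place of 4-hydroxypiperidin-1-yl on a carbonyl carbon. The two structures hold the same atoms, joined differently.

Within the data shown here, with no single-point step available among the measured compounds, the expectation for compound 3 rests on the change itself. The exchange at the amide keeps one hydrogen-bond acceptor and removes the donor; the step from compound 1 to compound 3 is expected to be small, a 1.3-fold lower number from compound 1 to compound 3 (0.13 log units; within the scatter), and not clearly beyond the scatter. Compound 3 is therefore estimated at 3500 nM, with a range from 1200 nM to 10000 nM.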

Compound 3, half-maximal inhibitory concentration: 11500 nM
Compound 3: middle estimate off by 3.3-fold (0.52 log units), on the low side; the whole stated range lies below it.
By their numbers in this assay, from the lowest: compound 2; then compound 1; then compound 3.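

In this assay, moving from 4-hydroxypiperidin-1-yl to 3-methoxypyrrolidin-1-yl on a carbonyl carbon gives a 2.4-fold higher number from compound 1 to compound 3 (0.39 log units; beyond the scatter) and so makes compound 3 the weaker inhibitor, a modest step but one that lies beyond the scatter. This shows that the position responds to the amide group even when the heavy atoms stay the same in number and kind: the two groups differ in ring size, in the hydrogen-bond donor present only in 4-hydroxypiperidin-1-yl, and in the defined stereocentre present only in 3-methoxypyrrolidin-1-yl. No measurement is available to explain the step.

The compounds shown change these features together, so they leave open how much of the step belongs to the ring and how much to the exchange of the hydroxyl for the methoxy group. Either 4-methoxypiperidin-1-yl or 3-hydroxypyrrolidin-1-yl on the same carbonyl carbon would separate the two, and the mirror-image form of 3-methoxypyrrolidin-1-yl would address the stereocentre.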